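Bromo for methyl on the hydroxyethoxy analogue

The compounds below may be only part of what the source reports. "The series", "measured", "known", "first", "only" and "open" are said of these compounds alone.

Measured so far in a functional assay on B16 cells (Mus musculus) for cytotoxicity, read by CCK-8 assay, with a stated time of 24 h; a lower number here means a stronger inhibitor, a higher number a weaker inhibitor:
compound 1 `COc1ccccc1Oc1c(N)nc(-c2cccc(C)c2)nc1Cl` gives 13100 nM
compound 2 `COc1ccccc1Oc1c(N)nc(-c2ccccc2F)nc1Cl` gives 13800 nM
compound 3 `COc1ccccc1Oc1c(N)nc(-c2cccc(C)c2)nc1OCCO` gives 70900 nM

Compound 3 carries the highest number of the three in this assay; both compound 1 and compound 2 lie beyond the scatter below it, and the step of a 5.4-fold higher number from compound 1 to compound 3 (0.73 log units; beyond the scatter) marks the shift that separates it from the chloro compound. Compound 4 `COc1ccccc1Oc1c(N)nc(-c2cccc(Br)c2)nc1OCCO` is the next member, differing from compound 3 by bromo in place of methyl on an aromatic carbon. Among the compounds with values here, no measured step exchanges bromo for methyl, so the only guidance comes from the one step that alters the aryl substituent, a 1.1-fold higher number from compound 1 to compound 2 (0.02 log units; within the scatter), which stayed within the scatter even though it moved the substituent as well as changing its kind. The other step, a 5.4-fold higher number from compound 1 to compound 3 (0.73 log units; beyond the scatter), concerns the chloro position and says nothing about the aryl ring. On that basis the change from compound 3 to compound 4 is expected to be small in this assay, with no direction to be read from the data: a 1.2-fold lower number from compound 3 to compound 4 (0.07 log units; within the scatter). Compound 4 is therefore estimated at 60000 nM, with a range from 25000 nM to 150000 nM, centred close to the value of compound 3.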

Compound 4, half-maximal inhibitory concentration: 21900 nM
The estimate for compound 4 lay 2.7-fold (0.44 log units) above the measured number; measured number below the stated range.
By their numbers in this assay, from the lowest: compounds 1, 2 and 4 (each within the scatter of the next); then compound 3.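

In this assay, the 3-methylphenyl to 3-bromophenyl change on the hydroxyethoxy compound gives a 3.2-fold lower number from compound 3 to compound 4 (0.51 log units; beyond the scatter), so this aryl substituent can shift the number beyond the scatter. Within the data shown here, the only earlier step at the aryl group, a 1.1-fold higher number from compound 1 to compound 2 (0.02 log units; within the scatter), was a different exchange made on a chloro compound and stayed within the scatter, so it gave no sign that this part of the molecule could register in this assay. No measured evidence available here bears on the reason for the step between the methyl and bromo compounds.

Still open, as far as these compounds go, is whether bromo in place of methyl gives a comparable step when chloro rather than 2-hydroxyethoxy occupies the other varied position, since a single pair cannot show whether the effect carries over from one compound type to the other. Also open, from the compounds shown here alone, is how a nitrile or a trifluoromethyl in place of the bromo would read in this assay, and likewise an amine or a longer chain in place of the 2-hydroxyethoxy.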